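The compounds below may be only part of what the source reports. "The series", "measured", "known", "first", "only" and "open" are said of these compounds alone.

Compound 1 `COc1nc(-c2ccncc2)ccc1[C@@H](c1ccccc1)[C@@](O)(CCN(C)C)c1cccc2ccccc12` — > 50 ug/mL
Compound 2 `COc1nc(-c2ccc(OC(F)(F)F)cc2)ccc1[C@@H](c1ccccc1)[C@@](O)(CCN(C)C)c1cccc2ccccc12` — > 50 ug/mL

In a toxicity assay on Vero cells (Chlorocebus sabaeus) for cytotoxicity (on this read-out lower numbers stand for higher toxicity in this test and higher numbers for lower toxicity in this test), compound 1 gives only a limit, > 50 ug/mL. Compound 2 also gives only a limit in this assay, > 50 ug/mL. The step that the two limits leave unreadable from compound 1 to compound 2 cannot be read because both values sit at the limit of > 50 ug/mL in this assay, at which 2 of the 2 values shown sit.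

Compound 3 `COc1nc(-c2ccccc2Cl)ccc1[C@@H](c1ccccc1)[C@@](O)(CCN(C)C)c1cccc2ccccc12` differs from compound 2 by 2-chlorophenyl in place of 4-(trifluoromethoxy)phenyl on an aromatic carbon. Among the measured compounds shown here, no measured step shows this change, and the only measured step stays unreadable, so no change beyond the scatter is expected in this assay. Compound 3 is expected to give 60 ug/mL in this assay, between 30 ug/mL and 120 ug/mL. The expected step is a step that the limit leaves unreadable from compound 2 to compound 3.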

Compound 3, half-maximal cytotoxic concentration: > 50 ug/mL
Compound 3: only a limit was reported; the forecaster's own chance of this, stated with the estimate: 75%; the middle value is on the limit's open side.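

Compound 3 also gives only a limit, so neither step to it, from compound 1 or from compound 2, can be read: the limit of > 50 ug/mL in this assay, at which 3 of the 3 values shown sit.

Where the true values of compound 1, compound 2 and compound 3 lie in this assay, and whether the exchanged groups change them, stays open.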